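Amide aryl variation on the shared core: compound 4

The compounds below may be only part of what the source reports. "The series", "measured", "known", "first", "only" and "open" are said of these compounds alone.

compound 1 `Cc1cccc(C)c1NC(=O)CSc1nnc(-c2ccoc2C)n1Cc1ccco1` — > 15800 nM
compound 2 `Cc1occc1-c1nnc(SCC(=O)Nc2cccc(Cl)c2)n1Cc1ccco1` — 2000 nM
compound 3 `COc1ccccc1NC(=O)CSc1nnc(-c2ccoc2C)n1Cc1ccco1` — > 15800 nM

Three compounds share the core of compound 1 and differ only in the aryl group on the amide-type nitrogen, all tested in a functional assay on CHO cells for antagonist activity at Orexin/Hypocretin receptor type 1 (Homo sapiens), read by FLIPR and calcium flux; on this read-out higher numbers stand for weaker inhibition and lower numbers for stronger inhibition. Compound 1, with 2,6-dimethylphenyl, gives only a limit, > 15800 nM. Compound 3, with 2-methoxyphenyl, likewise gives only a limit, > 15800 nM. Going by the values given here, compound 2, with 3-chlorophenyl, is the one member that gives a number, 2000 nM. Hence an at least 7.9-fold lower number from compound 1 to compound 2 (0.89 log units; beyond the scatter) and an at least 7.9-fold higher number from compound 2 to compound 3 (0.89 log units; beyond the scatter), while a step that the two limits leave unreadable from compound 1 to compound 3. Compound 3 therefore stands at the limit of > 15800 nM in this assay, at which 2 of the 3 values shown sit, the weak end of the three values.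

Compound 4 `Cc1occc1-c1nnc(SCC(=O)Nc2ccc(N(C)C)cc2)n1Cc1ccco1` carries 4-(dimethylamino)phenyl in place of 2-methoxyphenyl on an amide-type nitrogen. Among the compounds with values here, no measured step puts 4-(dimethylamino)phenyl on this nitrogen, and only 3-chlorophenyl has so far given a readable number; the two readable steps show only that changing the aryl group can move the read-out by at least the span between compound 3 and compound 2. The direction for compound 4 is open. The expectation is that compound 4 most likely stays near the limit, with some chance of a readable number, so the estimated step is an at least 1.7-fold lower number from compound 3 to compound 4 (0.24 log units; that floor lies within the scatter). Compound 4 is estimated at 9000 nM, between 2500 nM and 30000 nM.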

Compound 4, inhibition constant: 794 nM
Estimate against measurement, compound 4: 11-fold (1.05 log units) above; measured number outside the range, below it.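

In this assay there is a 2.5-fold lower number from compound 2 to compound 4 (0.40 log units; beyond the scatter) when 4-(dimethylamino)phenyl replaces 3-chlorophenyl, so the amide-type nitrogen now carries two aryl groups that give a number, and compound 4 is the strongest of the four. Against the two compounds that give only a limit the change is larger, with an at least 19-fold lower number from compound 3 to compound 4 (1.29 log units; beyond the scatter) and an at least 19-fold lower number from compound 1 to compound 4 (1.29 log units; beyond the scatter) as the aryl group changes from 2-methoxyphenyl and from 2,6-dimethylphenyl. Across these four compounds, with no exception, 3-chlorophenyl and 4-(dimethylamino)phenyl give numbers while 2-methoxyphenyl and 2,6-dimethylphenyl remain at a limit, which is not a number: the limit of > 15800 nM in this assay, at which 2 of the 4 values shown sit.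

On these data alone, whether the read-out follows the place of the group on the aryl ring or the group itself stays open, and a pair such as 4-chlorophenyl and 3-(dimethylamino)phenyl would separate the two. Equally open, as far as these compounds go, is how unsubstituted phenyl or 4-morpholinophenyl would read on this nitrogen, and how any part of the shared core outside this aryl group bears on the read-out.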